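Bromomethyl variant of the furan-linked naphthalene series

The source may hold more compounds than are shown below. What is called first, only, known or untested is meant among the compounds shown, and "the series" means these compounds.

Measured so far:
compound 1, `CCc1cccc2c(OC)c(-c3occ(C)c3C(=S)OC)ccc12`; in a functional assay on SK-BR-3 cells (Homo sapiens) for cytotoxicity, read by MTT assay, with a stated time of 72 h (a higher number here means that more compound is needed for the effect, a lower number that less compound is needed), compound 1 gives 6.3 ug/mL
compound 2, `CCOCc1c(C)coc1-c1ccc2c(CC)cccc2c1OC`; in this assay compound 2 gives only a limit, > 10 ug/mL

Compound 2 stands at the edge of what has been measured: its entry is a limit of the assay and not a number, as recorded in the limit of > 10 ug/mL in this assay, at which 1 of the 2 values shown sits. Within the data shown here, the one measured step, an at least 1.5-fold higher number from compound 1 to compound 2 (0.20 log units; that floor lies within the scatter), exchanges a group on an aromatic carbon and ends at this limit, so its size is known only as a floor.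

Compound 3, `CCc1cccc2c(OC)c(-c3occ(C)c3CBr)ccc12`, differs from compound 2 by bromo in place of ethoxy on a saturated chain carbon bound to an aromatic carbon. Among the measured compounds shown here, no measured step touches this exchange or this place on the scaffold; the only recorded step concerns another group and itself stops at the limit. The two measured entries therefore give only a span, from the number of compound 1 to the limit of compound 2, and nothing within that span favours a direction. For the measured compounds named here, with no step to lean on, the expectation for compound 3 is wide: an estimated step of an at least 1.6-fold lower number from compound 2 to compound 3 (0.22 log units; that floor lies within the scatter). Compound 3 is thus expected near 6 ug/mL, with a range from 1.5 ug/mL to 25 ug/mL, a limit being again quite possible.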

Compound 3, concentration for half-maximal effect: > 10 ug/mL
Compound 3: only a limit was reported; the forecaster's own chance of this, stated with the estimate: 35%; at least 1.6-fold (0.22 log units) between middle value and limit.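

In this assay compound 3 gives > 10 ug/mL as a limit of the assay and not a number. The exchange of ethoxymethyl to bromomethyl, on a saturated chain carbon bound to an aromatic carbon, thus ends at the same limit as compound 2, so the step between these two compounds cannot be read, and the limit now holds most of the series: the limit of > 10 ug/mL in this assay, at which 2 of the 3 values shown sit. Among these compounds, the one readable change is an at least 1.5-fold higher number from compound 1 to compound 3 (0.20 log units; that floor lies within the scatter) and, being only a floor, it does not place compound 3 apart from compound 1 beyond the usual scatter.

The compounds shown leave open how far past the limit compound 2 and compound 3 lie, and therefore whether bromo and ethoxy differ at all at this place on the shared core. Also open, on these data alone, is whether any group on this carbon gives a readable number in this assay, for example an amine, a carboxylic acid or a longer chain.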